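Amine variation on the chain in a quinazoline-like series

The compounds below may be only part of what the source reports. "The series", "measured", "known", "first", "only" and "open" are said of these compounds alone.

Measured so far:
compound 1 `CCN(CC)CCCOc1cc2ncnc(Nc3nc4ccc(C(=O)Nc5c(C)cccc5C)cc4s3)c2cc1OC`, > 100000 nM
compound 2 `COc1cc2c(Nc3nc4ccc(C(=O)Nc5c(C)cccc5Cl)cc4s3)ncnc2cc1OCCCN1CCC(C)CC1`, 9700 nM
compound 3 `COc1cc2c(Nc3nc4ccc(C(=O)Nc5c(C)cc(C)cc5C)cc4s3)ncnc2cc1OCCCN1CCCCC1`, 10300 nM

In a functional assay on A549 cells (Homo sapiens) for cytotoxicity, read by WST assay, with a stated time of 72 h (on this read-out higher numbers stand for weaker inhibition and lower numbers for stronger inhibition), compound 1 gives only a limit, > 100000 nM, and no number. This is the reading at the limit of > 100000 nM in this assay, at which 1 of the 3 values shown sits, so compound 1 stands at the weak end of what is shown. Compound 2 gives 9700 nM in this assay, and compound 3 gives 10300 nM; these two values sit within the scatter of each other, so no order between them is claimed.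

Compound 4 `COc1cc2c(Nc3nc4ccc(C(=O)Nc5c(C)cccc5C)cc4s3)ncnc2cc1OCCCN1CCC(C)CC1` has not been measured in this assay. It differs from compound 1 in one place: 4-methylpiperidin-1-yl in place of diethylamino on a saturated chain carbon, three bonds along the chain from an oxygen on an aromatic ring. Compound 2 and compound 3 both carry a cyclic amine at that place and both give numbers, while compound 1 with its open-chain amine gives only a limit. On that basis the step is expected to be a clear move toward stronger inhibition, beyond the scatter, though its size cannot be fixed from a limit. Compound 4 is estimated at 12000 nM, within 4000 nM to 60000 nM, which is the expected step of an at least 8.3-fold lower number from compound 1 to compound 4 (0.92 log units; beyond the scatter).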

Compound 4, half-maximal inhibitory concentration: 89700 nM
Compound 4: the middle estimate sits 7.5-fold (0.87 log units) below what was measured, and the stated range ends below it.
By their numbers in this assay, from the lowest: compounds 2 and 3 (each within the scatter of the next); then compound 4. At a limit, above all of these: compound 1.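

In this assay, 4-methylpiperidin-1-yl in place of diethylamino on this chain carbon gives an at least 1.1-fold lower number from compound 1 to compound 4 (0.04 log units; that floor lies within the scatter), so a cyclic amine here is not shown to change the read-out on its own. With the amine held, methyl in place of chloro on an aromatic carbon gives a 9.2-fold higher number from compound 2 to compound 4 (0.97 log units; beyond the scatter), so the number of compound 2 cannot be credited to the cyclic amine alone. The amine step can be given only as a floor, because compound 1 remains a limit: the limit of > 100000 nM in this assay, at which 1 of the 4 values shown sits.

On these data alone, the true size of the amine step remains open, as does the effect of diethylamino in a compound carrying the chloro group. Also open, as far as these compounds go, is how a morpholine or a 4-methylpiperazine at the end of the same chain would read.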